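Aryl amine variation in a cytotoxicity series

The source may hold more compounds than are shown below. What is called first, only, known or untested is meant among the compounds shown, and "the series" means these compounds.

Measured so far:
compound 1, `FC(F)(F)c1ccc(CSc2nc(Nc3cccc(Br)c3)c3ccccc3n2)cc1`: 22100 nM
compound 2, `O=[N+]([O-])c1ccc(Nc2nc(SCc3ccc(C(F)(F)F)cc3)nc3ccccc23)cc1`: 8670 nM
compound 3, `CCOc1ccc(Nc2nc(SCc3ccc(C(F)(F)F)cc3)nc3ccccc23)cc1`: 23000 nM

Three compounds share one core and differ only in the aryl group on the nitrogen on the aromatic ring. Read in a functional assay on MDA-MB-231 cells (Homo sapiens) for cytotoxicity, read by MTT assay, with a stated time of 72 h (a lower number here means a stronger inhibitor, a higher number a weaker inhibitor), compound 3 carries the highest of the three numbers, but its nearest neighbour is compound 1, separated by a 1.0-fold higher number from compound 1 to compound 3 (0.02 log units; within the scatter), which is within the scatter. Going by the values given here, the only step that reaches beyond the scatter is a 2.7-fold higher number from compound 2 to compound 3 (0.42 log units; beyond the scatter), and the matching step a 2.5-fold lower number from compound 1 to compound 2 (0.41 log units; beyond the scatter) is of the same modest size, so the measured range so far is narrow.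

Compound 4, `COc1cc(Nc2nc(SCc3ccc(C(F)(F)F)cc3)nc3ccccc23)cc(OC)c1`, is not yet measured. It differs from compound 3 as follows: 3,5-dimethoxyphenyl in place of 4-ethoxyphenyl on a nitrogen on an aromatic ring. Among the compounds with values here, no measured pair makes this exact change. Within the data shown here, the steps that bear on it are the exchanges of the aryl group, a 1.0-fold higher number from compound 1 to compound 3 (0.02 log units; within the scatter) and a 2.5-fold lower number from compound 1 to compound 2 (0.41 log units; beyond the scatter), one within the scatter and one modest. On that basis the step of a 1.2-fold lower number from compound 3 to compound 4 (0.06 log units; within the scatter) is expected to stay near the scatter in this assay, with no clear direction. Compound 4 is estimated at 20000 nM, within a range from 8000 nM to 50000 nM.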

Compound 4, half-maximal inhibitory concentration: 16100 nM
Beside the measured number, compound 4's estimate is 1.2-fold (0.09 log units) above it; the measured number falls inside the stated range.
By their numbers in this assay, from the lowest: compounds 2, 4, 1 and 3 (each within the scatter of the next, the first and the last beyond it).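

Working notes: in this assay, the 3,5-dimethoxyphenyl group of compound 4 cannot be separated from any of the other three aryl groups on the nitrogen, with a 1.4-fold lower number from compound 3 to compound 4 (0.15 log units; within the scatter), a 1.4-fold lower number from compound 1 to compound 4 (0.14 log units; within the scatter) and a 1.9-fold higher number from compound 2 to compound 4 (0.27 log units; within the scatter). The earlier compounds shown here showed a step beyond the scatter, a 2.7-fold higher number from compound 2 to compound 3 (0.42 log units; beyond the scatter), but compound 4 stands within the scatter of both of those compounds, so this position still shows only a narrow range across four substituted phenyl groups, and exchanging 4-ethoxyphenyl for 3,5-dimethoxyphenyl gives no clear shift. Nothing available accounts for any of these steps or for the one beyond the scatter.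

Every group shown at this position is a substituted phenyl, so it remains open whether a pyridine ring, a phenyl carrying a carboxylic acid or a morpholine, or a cyclohexyl group would move the number clearly out of this band. The 4-trifluoromethylbenzyl group on sulfur and the shared core are also constant throughout, which leaves their contribution to the cytotoxicity open.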